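The source may report more compounds than this note shows. Statements on the series, on what has been measured and on what is new or still open speak of the compounds shown alone.

Measured compounds:
- Compound 1, `COc1ccc(F)cc1CNCCCNc1ccnc2cc(Cc3ccc(C#N)cc3)ccc12`, gives 9.47.
- Compound 2, `CN(C)c1cccc(Oc2ccc3c(NCCCNCc4ccco4)ccnc3c2)c1`, gives 9.28.
- Compound 3, `COc1ccc(F)cc1CNCCCNc1ccnc2cc(Oc3cccc(N(C)C)c3)ccc12`, gives 9.28.

In a physicochemical assay for acid dissociation, compound 2 stands level with compound 3, and the gap between compound 2 and compound 1 lies within the usual scatter, so the three values cannot be ranked. The step from compound 2 to compound 4, `COc1ccccc1Oc1ccc2c(NCCCNCc3ccco3)ccnc2c1`, is 2-methoxyphenyl in place of 3-(dimethylamino)phenyl on an oxygen on an aromatic ring. Within the data shown here, two measured steps bear on it. The change at the far end of the shared core, a number 0.19 log units lower from compound 1 to compound 3 (within the scatter), altered the read-out only within the scatter, although it swapped a larger group than the present one. The change at the other end of the linker, no change at the digits printed from compound 2 to compound 3 (within the scatter), also left the read-out unchanged. Both steps suggest that swapping one aryl group for another on the aromatic ether oxygen does not move this assay beyond the scatter, so a step of no change at the digits printed from compound 2 to compound 4 (within the scatter) is expected. Compound 4 is therefore estimated at 9.28, with a range from 8.95 to 9.6.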

Compound 4, acid dissociation constant: 9.28
Compound 4: middle estimate and measured number agree at the digits printed; the range from low to high includes it.
By their numbers in this assay, from the lowest: compounds 2, 3, 4 and 1 (each within the scatter of the next).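

With the ether oxygen kept in place and the furan-2-yl end unchanged, exchanging only the ring on that oxygen gives no change at the digits printed from compound 2 to compound 4 (within the scatter) in this assay. The earlier steps shown here did not isolate this exchange, and here 3-(dimethylamino)phenyl, which holds a nitrogen, gives way to 2-methoxyphenyl, which holds an oxygen, with no shift beyond the scatter. The substituent and its place on the ring change together, so this pair cannot separate the two, and nothing available explains the result. On these data alone, it remains open whether a much different group on this oxygen, such as a carboxylic acid or a piperazine, would also leave the number within the scatter. As far as these compounds go, the same exchange with the 5-fluoro-2-methoxyphenyl end in place of furan-2-yl also remains open.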